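The compounds below may be only part of what the source reports. "The series", "measured", "known", "first", "only" and "open" are said of these compounds alone.

Compound 1, `COc1ccc([C@@H]2CC(=O)c3c(O)cc(OCc4cn(Cc5ccccc5C#N)nn4)cc3O2)cc1O`: 14600 nM
Compound 2, `COc1ccc([C@@H]2C/C(=N\O)c3c(O)cc(OCc4cn(Cc5ccccc5F)nn4)cc3O2)cc1O`: 5710 nM
Compound 3, `COc1ccc([C@@H]2C/C(=N\O)c3c(O)cc(OCc4cn(Cc5ccccc5C)nn4)cc3O2)cc1O`: 18000 nM

All three compounds share one core and were measured in a functional assay on RAW264.7 cells (Mus musculus) for inhibition, read by Griess assay, with stated times of 2 h and 24 h; on this read-out higher numbers stand for weaker inhibition and lower numbers for stronger inhibition. Compound 1 stands second highest of the three numbers; compound 3 gives a number only slightly higher and within the scatter, so no order between those two can be claimed, whereas compound 2 gives a number clearly lower, beyond the scatter. Going by the values given here, the single step between compounds that differ in one place is a 3.2-fold higher number from compound 2 to compound 3 (0.50 log units; beyond the scatter); it lies on a different pair and on a substituent of the aromatic ring.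

Compound 4, `COc1ccc([C@@H]2CC(=O)c3c(O)cc(OCc4cn(CCCO)nn4)cc3O2)cc1O`, has not yet been measured in this assay. Its difference from compound 1 is 2-hydroxyethyl in place of 2-cyanophenyl on a saturated chain carbon bound to an aromatic nitrogen. Among the compounds with values here, no measured step bears directly on this change: the one step available concerns a substituent on the six-membered aromatic ring that compound 4 no longer carries, and it was modest. The present change is larger, removing that ring altogether, so a shift somewhat beyond the scatter in either direction is possible, and a higher number, meaning weaker inhibition, is expected as the more likely outcome, with wide uncertainty. Compound 4 is therefore estimated at 22000 nM, with a range from 7000 nM to 70000 nM, which corresponds to an expected step of a 1.5-fold higher number from compound 1 to compound 4 (0.18 log units; within the scatter).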

Compound 4, half-maximal inhibitory concentration: 16700 nM
Estimate against measurement, compound 4: 1.3-fold (0.12 log units) above, and the stated range covers the measured number.
By their numbers in this assay, from the lowest: compound 2; then compounds 1, 4 and 3 (each within the scatter of the next).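

In this assay, replacing 2-cyanophenyl with 2-hydroxyethyl on a saturated chain carbon bound to an aromatic nitrogen gives a 1.1-fold higher number from compound 1 to compound 4 (0.06 log units; within the scatter), so on the core of compound 1 the read-out does not separate these two groups, even though the exchange removes the six-membered aromatic ring and the nitrile. The earlier step, a 3.2-fold higher number from compound 2 to compound 3 (0.50 log units; beyond the scatter), showed that a single substituent on that aromatic ring can matter on the core of compound 2, whereas this new pair shows that removing the whole 2-cyanophenyl group on the core of compound 1 leaves no readable difference. No measured evidence accounts for either result, so the absence of a difference here has no stated explanation.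

The compounds shown leave open whether the same exchange would also leave the number unchanged on the core of compound 2, where the 2-fluorophenyl-bearing compound gives the lowest number of the set. They also leave open what a primary amine, a carboxylic acid or a longer alkyl chain ending in hydroxyl would do at this place on the core of compound 1.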